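Shortening the Chain of a Dicarboxylic Acid Inhibitor

This account rests on a few compounds, and the source may have more. Where it says the series, first, only, none or still open, it means among the compounds named here.

Measured so far:
compound 1 `CC(C)(CCCCCCCCCCC(C)(C)CC(=O)O)CC(=O)O` — 80000 nM
compound 2 `CC(C)(CCCCCCCCCCCCCCCCC(C)(C)CC(=O)O)CC(=O)O` — 400000 nM

In a functional assay (Hepatocyte) for inhibition, with Rattus norvegicus as the target (on this read-out lower numbers stand for stronger inhibition and higher numbers for weaker inhibition), compound 1 gives 80000 nM and compound 2 gives 400000 nM. Compound 2 stands highest of the two numbers, and its gap to compound 1 lies beyond the scatter. Compound 3 `CC(C)(CCCCCCCCCCCCCCC(C)(C)CC(=O)O)CC(=O)O` has not yet been measured; it differs from compound 2 in one place: 1-(carboxymethyl)-1-methylethyl in place of 3-(carboxymethyl)-3-methylbutyl on a saturated chain carbon, ten or more bonds along the chain from a carbonyl carbon. Within the data shown here, no step between measured compounds is known. Because compound 1 gives 80000 nM with the shorter chain, compound 3 is expected to show a lower number than compound 2. For compound 3 the expected step is a 2.0-fold lower number from compound 2 to compound 3 (0.30 log units; within the scatter). The estimate for compound 3 is 200000 nM, within 80000 nM to 500000 nM.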

Compound 3, half-maximal inhibitory concentration: 300000 nM
Estimate against measurement, compound 3: 1.5-fold (0.18 log units) below; the measured number falls inside the stated range.
By their numbers in this assay, from the lowest: compound 1; then compounds 3 and 2 (each within the scatter of the next).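

In this assay, replacing 3-(carboxymethyl)-3-methylbutyl with 1-(carboxymethyl)-1-methylethyl gives a 1.3-fold lower number from compound 2 to compound 3 (0.12 log units; within the scatter). Among these compounds, this is the first direct comparison of a single change at this position, on a saturated chain carbon, and the two numbers cannot be told apart. No measurement shown here explains this result. From the compounds shown here alone, it remains open whether an amide or an amine at this position, in place of the carboxylic acid group, would shift the number beyond the scatter.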